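The source may hold more compounds than are shown below. What is called first, only, known or untested is meant among the compounds shown, and "the series" means these compounds.

Compound 1, with structure `COc1ccc(/C=C/C(=O)/C=C/c2cc3ccccc3nc2Oc2ccccc2)c(OC)c1`, was tested in a functional assay on HeLa cells (Homo sapiens) for cytotoxicity, read by MTT assay, with a stated time of 48 h; on this read-out higher numbers stand for weaker inhibition and lower numbers for stronger inhibition. In this assay compound 1 gives > 10000 nM, which is a limit of the assay and not a number, so its true position is not fixed (the limit of > 10000 nM in this assay, at which 1 of the 2 values shown sits). Compound 2, with structure `COc1cc(OC)c(OC)cc1/C=C/C(=O)/C=C/c1cc2ccccc2nc1Oc1ccccc1`, gives 12200 nM in this assay. The step that the limit leaves unreadable from compound 1 to compound 2 is methoxy in place of hydrogen on an aromatic carbon. Compound 3 has structure `COc1ccc(/C=C/C(=O)/C=C/c2cc3ccccc3nc2Oc2cccc(Cl)c2)c(OC)c1` and differs from compound 1 by chloro in place of hydrogen on an aromatic carbon. Among the compounds with values here, no measured step involves chloro in place of hydrogen, and the single measured step is unreadable, so no change beyond the scatter can be expected in this assay, in either direction. Compound 3 is therefore estimated at 12000 nM, within 4000 nM to 40000 nM. The expected step that the limit leaves unreadable from compound 1 to compound 3 is small, and a limit rather than a number is again likely.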

Compound 3, half-maximal inhibitory concentration: > 10000 nM
Compound 3: no number, only a limit; the forecaster's own chance of this, stated with the estimate: 50%; the middle value does not contradict the limit.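

In this assay compound 3 gives > 10000 nM, which is a limit and not a number. Compound 1 also stands at a limit, so no step can be read between compound 1 and compound 3. The compounds shown leave open where these two truly lie, and whether chloro in place of hydrogen shifts the value in either direction.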